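Inverting the ring stereocentre of compound 3

A few compounds are considered here, and "the series" means these few. Any claim that something is new, unique, unknown or untested is made for them only; others in the source may bear on it.

Among the compounds with values here, in an ADME assay on microsomes from liver (Rattus norvegicus) for metabolic stability, with a stated time of 60 min, tested at 1 uM (on this read-out higher numbers stand for a more stable compound and lower numbers for a less stable compound), compound 3 (`COc1cc(-c2cnn3cc(OC)c([C@@H]4COC(C)(C)C4)nc23)ccn1`) gives 30%, the lowest of the three numbers so far. Compound 1 (`COc1cc(-c2cnn3cc(OC)c(-c4cnn(C)c4)nc23)ccn1`) gives 56% and compound 2 (`COc1cc(-c2cnn3cc(OC)c(C(C)(C)O)nc23)ccn1`) gives 92%. Compound 4 (`COc1cc(-c2cnn3cc(OC)c([C@H]4COC(C)(C)C4)nc23)ccn1`) is the next structure to consider: the two compounds have the same atoms and bonds and differ only in configuration as drawn: 1 of 1 stereo elements differ; a stereocentre at a saturated ring carbon is drawn R in compound 3 and S in compound 4.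

The measured steps all exchange the group on the aromatic carbon: a number 36 percentage points higher from compound 1 to compound 2 (beyond the scatter), a number 26 percentage points lower from compound 1 to compound 3 (beyond the scatter) and a number 62 percentage points lower from compound 2 to compound 3 (beyond the scatter). These steps are large or modest and all lie beyond the scatter, but they show only how far the read-out moves when that group is exchanged. Within the data shown here, no pair of stereoisomers has been measured, so the data give no direction for a change of configuration alone.

The estimate therefore starts from compound 3 at 30%, with no step beyond the scatter expected and a wide range kept open. The expected change is a number 5 percentage points higher from compound 3 to compound 4 (within the scatter). For compound 4 the estimated value is 35%, with an expected range from 15% to 58%.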

Compound 4, percent of the compound remaining: 30%
Estimate against measurement, compound 4: 5 percentage points above, and the stated range covers the measured number.
By their numbers in this assay, from the lowest: compounds 3 and 4 (each within the scatter of the next); then compound 1; then compound 2.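

In this assay the step is no change at the digits printed from compound 3 to compound 4 (within the scatter), so in the only stereoisomer pair shown, the stereocentre at the saturated ring carbon gives no readable change, and the comparison rests on a single variable: the fact that compounds 3 and 4 differ only in the configuration as drawn The S form also keeps the gaps seen for the R form when the group on the aromatic carbon is exchanged: a number 62 percentage points lower from compound 2 to compound 4 (beyond the scatter) and a number 26 percentage points lower from compound 1 to compound 4 (beyond the scatter). Among these four compounds, the read-out therefore moves with the group on the aromatic carbon and not with the drawn configuration of the ring.

The compounds shown do not say which part of the five-membered non-aromatic ring group accounts for its gap to compound 2. On these data alone, it also remains open whether an amine or a carboxylic acid on that ring would keep the two configurations level or bring either closer to compound 2 at 92%.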